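The compounds below may be only part of what the source reports. "The series", "measured", "known", "first", "only" and "open" are said of these compounds alone.

Compound 1 `CCCN1CCN(c2ccc(S(=O)(=O)Oc3cccc(OC)c3)cc2)C1=O` gives 10000 nM in a functional assay on M21 cells (Homo sapiens) for antiproliferative activity, read by sulforhodamine B assay, with a stated time of 48 h; a higher number here means a weaker inhibitor, a lower number a stronger inhibitor. Compound 2 `CCCN1CCN(c2ccc(S(=O)(=O)Oc3cccc(F)c3)cc2)C1=O` differs from it by fluoro in place of methoxy on an aromatic carbon, and in this assay compound 2 gives 12000 nM, a step of a 1.2-fold higher number from compound 1 to compound 2 (0.08 log units; within the scatter). Compound 3 `CCCCN1CCN(c2ccc(S(=O)(=O)Oc3cccc(OC)c3)cc2)C1=O` carries a second core, which differs from the core of compound 1 by methyl in place of hydrogen on a saturated chain carbon, three bonds along the chain from an amide-type nitrogen in a ring; in this assay compound 3 gives 30000 nM, which is a 3.0-fold higher number from compound 1 to compound 3 (0.48 log units; beyond the scatter). Compound 4 `CCCCN1CCN(c2ccc(S(=O)(=O)Oc3cccc(F)c3)cc2)C1=O` has not yet been measured. It differs from compound 3 by fluoro in place of methoxy on an aromatic carbon, the same change as that made from compound 1 to compound 2, at the same place on the ring. Since that earlier change gave a 1.2-fold higher number from compound 1 to compound 2 (0.08 log units; within the scatter), a step of similar size is expected for compound 4 , namely a 1.2-fold higher number from compound 3 to compound 4 (0.08 log units; within the scatter). Compound 4 is therefore estimated at 36000 nM, most likely falling between 18000 nM and 70000 nM.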

Compound 4, half-maximal inhibitory concentration: > 100000 nM
Compound 4: a limit, no number (the forecaster's own chance of this, stated with the estimate: 25%); middle value at least 2.7-fold (0.44 log units) from the limit.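

In this assay compound 4 gives > 100000 nM, which is a limit of the assay and not a number. Fluoro in place of methoxy gave an at least 3.3-fold higher number from compound 3 to compound 4 (0.52 log units; beyond the scatter), so the change did not carry over from the core of compound 1 to the core of compound 3 at the same size: the same change on two cores in this assay, a 1.2-fold higher number (0.08 log units; within the scatter) from compound 1 to compound 2 and an at least 3.3-fold higher number (0.52 log units; beyond the scatter) from compound 3 to compound 4, at least 2.7-fold (0.44 log units) apart, beyond the scatter of two such steps The data do not show the true size of that step, and the same holds for the added methyl, which gave an at least 8.3-fold higher number from compound 2 to compound 4 (0.92 log units; beyond the scatter) and also did not keep its earlier size: the same change on two cores in this assay, a 3.0-fold higher number (0.48 log units; beyond the scatter) from compound 1 to compound 3 and an at least 8.3-fold higher number (0.92 log units; beyond the scatter) from compound 2 to compound 4, at least 2.7-fold (0.44 log units) apart, beyond the scatter of two such steps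

The compounds shown leave open whether a chloro or hydroxy group at this place would follow the same course. They also leave open how a longer chain on the amide-type nitrogen would behave.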